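The compounds below may be only part of what the source reports. "The series", "measured", "known", "first", "only" and "open" are said of these compounds alone.

Measured compounds:
Compound 1, `COc1cc2c(Nc3ccc(C#N)cc3)ncnc2cc1OCCCN1CCC(C)CC1`, in a functional assay on A549 cells (Homo sapiens) for antiproliferative activity, read by MTT assay, with a stated time of 72 h (on this read-out lower numbers stand for stronger inhibition and higher numbers for weaker inhibition), gives 32300 nM.
Compound 2, `COc1cc2c(Nc3ccc(C#N)cc3)ncnc2cc1OCCCN1CCN(C)CC1`, in this assay gives 48800 nM.
Compound 3, `COc1cc2c(Nc3cccc(C#N)c3)ncnc2cc1OCCCN1CCC(C)CC1`, in this assay gives 18700 nM.

Compound 1 and compound 2 differ only at the end of the propyl chain: 4-methylpiperazin-1-yl in place of 4-methylpiperidin-1-yl on a saturated chain carbon, three bonds along the chain from an oxygen on an aromatic ring. That change produced a 1.5-fold higher number from compound 1 to compound 2 (0.18 log units; within the scatter), so on this pair the two side chains are indistinguishable within the usual scatter. Compound 1 and compound 3 carry the same side chain and differ in the aryl group on the amine: 3-cyanophenyl in place of 4-cyanophenyl on a nitrogen on an aromatic ring. This gave a 1.7-fold lower number from compound 1 to compound 3 (0.24 log units; within the scatter), again within the scatter. Compound 2 and compound 3 have no single-point relation here; their two values simply stand as given.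

Compound 4, `COc1cc2c(Nc3cccc(C#N)c3)ncnc2cc1OCCCN1CCN(C)CC1`, has not yet been measured. It relates to compound 3 exactly as compound 2 relates to compound 1: 4-methylpiperazin-1-yl in place of 4-methylpiperidin-1-yl on a saturated chain carbon, three bonds along the chain from an oxygen on an aromatic ring. The place description is the same word for word, so this is the same change, now on the core of compound 3 rather than that of compound 1. Going by the values given here, with only one earlier instance, the expectation rests on that single step. The step from compound 3 to compound 4 in this assay is expected to be about a 1.5-fold higher number from compound 3 to compound 4 (0.18 log units; within the scatter), set beside the measured 1.5-fold higher number from compound 1 to compound 2 (0.18 log units; within the scatter), because a 1.7-fold lower number from compound 1 to compound 3 (0.24 log units; within the scatter) shows the core change itself barely moved the read-out, giving no reason to expect the side-chain swap to act differently here. Compound 4 is therefore estimated at 28000 nM, with a plausible range from 12000 nM to 65000 nM; all four compounds are weak in this assay.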

Compound 4, half-maximal inhibitory concentration: 27700 nM
The estimate for compound 4 lay 1.0-fold (0.00 log units) above the measured number; low and high end bracket the measured number.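

In this assay, the swap to 4-methylpiperazin-1-yl from 4-methylpiperidin-1-yl on the core of compound 3 gave a 1.5-fold higher number from compound 3 to compound 4 (0.17 log units; within the scatter), and the step carried over from one core to the other with no gap that can be told from the scatter: the same change on two cores in this assay, a 1.5-fold higher number (0.18 log units; within the scatter) from compound 1 to compound 2 and a 1.5-fold higher number (0.17 log units; within the scatter) from compound 3 to compound 4, 1.0-fold (0.01 log units) apart, within the scatter of two such steps. Read the other way, 3-cyanophenyl in place of 4-cyanophenyl gave a 1.8-fold lower number from compound 2 to compound 4 (0.25 log units; within the scatter), and this step also matches its earlier counterpart: the same change on two cores in this assay, a 1.7-fold lower number (0.24 log units; within the scatter) from compound 1 to compound 3 and a 1.8-fold lower number (0.25 log units; within the scatter) from compound 2 to compound 4, 1.0-fold (0.01 log units) apart, within the scatter of two such steps. The four compounds therefore behave as additive within the scatter, but each of these steps is itself within the scatter, so the agreement does not show that either change has a real effect of its own, and two cores say nothing about a third.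

Still open, on these data alone, is whether a morpholin-4-yl group at the end of the propyl chain, a longer butyl chain, or a chloro or ethynyl group in place of the nitrile would move the number beyond the scatter. Also open, as far as these compounds go, is whether a larger step, once found, would carry from core to core as closely as these small ones do in this assay.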